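Trifluoromethylbenzoyl Ester in Place of Succinate on a Triterpenoid

The compounds below may be only part of what the source reports. "The series", "measured", "known", "first", "only" and "open" are said of these compounds alone.

Measured compounds:
- compound 1 `CC1=CC[C@H]2[C@@H]1CC=C(C)[C@@H](CCC1=C(C)CC[C@@H]3OC(C)(C)[C@@H](O)CC[C@@]13C)C2(C)C`: > 50000 nM
- compound 2 `CC1=CC[C@H]2[C@H](CC[C@]2(C)O)C(C)(C)[C@@H]1CC[C@H]1[C@]2(C)CC[C@H](OC(=O)CCC(=O)O)C(C)(C)O[C@H]2CC[C@@]1(C)O`: 27900 nM
- compound 3 `CC1=CC[C@H]2[C@@H]1CC=C(C)[C@@H](CC[C@H]1[C@]3(C)CC[C@H](OC(=O)CCC(=O)O)C(C)(C)O[C@H]3CC[C@@]1(C)O)C2(C)C`: 29600 nM

In a functional assay on MDA-MB-231 cells (Homo sapiens) for antiproliferative activity, read by MTT assay, with a stated time of 72 h (on this read-out higher numbers stand for weaker inhibition and lower numbers for stronger inhibition), compound 1 reaches only a limit, > 50000 nM, so no number is known for it. Compound 2 gives 27900 nM in this assay, the lowest of the two numbers reported. Compound 3 gives 29600 nM, and its gap to compound 2 lies within the usual scatter, so the two cannot be told apart.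

Compound 4 `CC1=CC[C@H]2[C@H](CC[C@]2(C)O)C(C)(C)[C@@H]1CC[C@H]1[C@]2(C)CC[C@H](OC(=O)c3ccc(C(F)(F)F)cc3)C(C)(C)O[C@H]2CC[C@@]1(C)O` has not yet been measured. It differs from compound 2 in one place: 4-(trifluoromethyl)phenyl in place of 2-carboxyethyl on a carbonyl carbon. The 2-carboxyethyl group leaves and a 4-(trifluoromethyl)phenyl group enters on the carbonyl carbon of the ester. No measured pair in this set shows what such an exchange does, so the direction of the step rests on no shown evidence. The step from compound 2 to compound 4 is expected to be modest, a 1.9-fold lower number from compound 2 to compound 4 (0.27 log units; within the scatter), with a lower number somewhat more likely than a higher one. Compound 4 is therefore estimated at 15000 nM, within a range from 4000 nM to 50000 nM.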

Compound 4, half-maximal inhibitory concentration: 19500 nM
The estimate for compound 4 lay 1.3-fold (0.11 log units) below the measured number; the measured number falls inside the stated range.
By their numbers in this assay, from the lowest: compounds 4, 2 and 3 (each within the scatter of the next). At a limit, above all of these: compound 1.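

Replacing the 2-carboxyethyl group with 4-(trifluoromethyl)phenyl on the carbonyl carbon of the ester gives, in this assay, a 1.4-fold lower number from compound 2 to compound 4 (0.16 log units; within the scatter), so compound 2 and compound 4 cannot be told apart. This exchange removes the hydrogen-bond donor of the 2-carboxyethyl group and brings in an aromatic ring, yet the result shows that this position does not need that group for activity of this modest size in this assay. Compound 1 gives only a limit, so no step to it can be read: the limit of > 50000 nM in this assay, at which 1 of the 4 values shown sits.

As far as these compounds go, whether an amine, an unsubstituted phenyl or a longer chain on the same carbonyl carbon would move the number beyond the scatter remains open. The compounds shown also leave open whether the same exchange would behave alike on compound 3.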